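The source may report more compounds than this note shows. Statements on the series, on what has been measured and on what is new or still open speak of the compounds shown alone.

Compound 1, with the structure `CCN(C)Cc1c(OC)cc(OC)c(C(=O)/C=C/c2ccccc2Cl)c1O`, is the reference point of this account. In a functional assay on A549 cells (Homo sapiens) for antiproliferative activity, with a stated time of 72 h (on this read-out lower numbers stand for stronger inhibition and higher numbers for weaker inhibition), compound 1 gives 1300 nM, the lowest of the two numbers reported. Compound 2, `COc1cc(O)c2c(=O)cc(-c3ccccc3Cl)oc2c1CN1CCCCC1`, gives 45500 nM in this assay, a markedly higher number than compound 1 and well beyond the usual scatter. Compound 3, `COc1cc(OC)c2c(=O)cc(-c3ccccc3Cl)oc2c1CN1CCCCC1`, reaches only the limit > 150000 nM in this assay, so for compound 3 no number is known. Among the compounds with values here, the single step between measured compounds is an at least 3.2-fold higher number from compound 2 to compound 3 (0.51 log units; beyond the scatter), and it concerns a different change from the one examined here; compound 3 sitting at the limit of > 150000 nM in this assay, at which 1 of the 3 values shown sits, means the true size of that step may be larger.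

Compound 4, `COc1cc(OC)c(C(=O)/C=C/c2ccccc2Cl)c(O)c1CN(C)CCCN(C)C`, is compound 1 carrying ((dimethylamino)methyl in place of hydrogen on a saturated chain carbon, two bonds along the chain from an amine nitrogen). Within the data shown here, none of the measured compounds differs from another in this way, so no measured step bears directly on the change, and the step that is known belongs to an unrelated part of the molecule. Without a comparable precedent, the expectation is a step of no more than the usual scatter in either direction. Compound 4 is therefore estimated to give about 1000 nM, expected between 300 nM and 4000 nM. That estimate amounts to an expected 1.3-fold lower number from compound 1 to compound 4 (0.11 log units; within the scatter).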

Compound 4, half-maximal inhibitory concentration: 3100 nM
Compound 4: the middle estimate sits 3.1-fold (0.49 log units) below what was measured, and the stated range covers the measured number.
By their numbers in this assay, from the lowest: compound 1; then compound 4; then compound 2. At a limit, above all of these: compound 3.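

Within the data shown here, the result gives a first measured reading of this position. In this assay the step from hydrogen to (dimethylamino)methyl on a saturated chain carbon, two bonds along the chain from an amine nitrogen, brings a 2.4-fold higher number from compound 1 to compound 4 (0.38 log units; beyond the scatter) and so lies beyond the scatter but remains modest, which shows that the amine side chain of the core of compound 1 can carry this extension, read also as ethyl(methyl)amino to (3-(dimethylamino)propyl)(methyl)amino, at only a modest cost in this read-out. Nothing in the data shown bears on why the number moves in this direction with this change.

Going by these compounds, it remains open whether the step follows from the second amine or from the longer chain alone, a question that a plain propyl group, or a 3-hydroxypropyl group in place of the 3-(dimethylamino)propyl group, would address. Also open, on these data alone, is how a shorter 2-(dimethylamino)ethyl chain, a terminal morpholine or a terminal carboxylic acid at this position would compare, and whether the same extension would act alike on the core of compound 2.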